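Compound 2 aryl swap: growth inhibition working notes

This account rests on a few compounds, and the source may have more. Where it says the series, first, only, none or still open, it means among the compounds named here.

In a functional assay on A549 cells (Homo sapiens) for inhibition, read by MTT assay, with a stated time of 48 h (a lower number here means a stronger inhibitor of growth, a higher number a weaker inhibitor of growth), compound 1 `Cc1ccc(C(=O)N2N=C(c3ccccc3)CC2c2cn(C)c3ccccc23)cn1` gives 1190 nM and compound 2 `Cn1cc(C2CC(c3ccc(F)cc3)=NN2C(=O)c2cccnc2)c2cc(Br)ccc21` gives 1380 nM as its value. Within the data shown here, these two values lie within the scatter of each other, so compound 2 stands level with compound 1 on the numbers so far. Among the measured compounds shown here, no pair of measured compounds differs in one place only, so the effect of a single change remains unmeasured.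

Compound 3 `COc1ccc(C2=NN(C(=O)c3cccnc3)C(c3cn(C)c4ccc(Br)cc34)C2)cc1OC` keeps the rest of compound 2 and carries 3,4-dimethoxyphenyl in place of 4-fluorophenyl on a carbon with a double bond to nitrogen in the shared core. In this assay no step beyond the scatter is expected, with only a slight lean towards weaker inhibition. The expected change is a 1.2-fold higher number from compound 2 to compound 3 (0.06 log units; within the scatter) as a best guess. An estimated value for compound 3 of 1600 nM (expected range 650 nM to 4000 nM) closes these notes.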

Compound 3, concentration for 50% growth inhibition: 2380 nM
Estimate against measurement, compound 3: 1.5-fold (0.17 log units) below; low and high end bracket the measured number.
By their numbers in this assay, from the lowest: compounds 1, 2 and 3 (each within the scatter of the next).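

In this assay, among these compounds, the swap of 4-fluorophenyl for 3,4-dimethoxyphenyl on the carbon with a double bond to nitrogen gives the first step that can be read at a single place (a 1.7-fold higher number from compound 2 to compound 3 (0.24 log units; within the scatter)). At this position, then, a phenyl group bearing two methoxy groups and two hydrogen-bond acceptors stands in for 4-fluorophenyl without a change beyond the scatter, though this is one step and sets no pattern. Nothing measured here bears on what lies behind the size of this step.

On these data alone, whether any group at this position can produce a step beyond the scatter stays open, for instance a phenyl ring carrying an amine or a carboxylic acid. As far as these compounds go, the separate effects of the other places in which compound 1 and compound 2 differ also stay open.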